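The source may hold more compounds than are shown below. What is called first, only, known or untested is meant among the compounds shown, and "the series" means these compounds.

Measured so far:
- compound 1 `C=C1[C@@H](OC(C)=O)C[C@@H]2[C@](C)(CO[Si](C)(C)C(C)(C)C)[C@H](OC(C)=O)CC[C@@]2(C)[C@@H]1C[C@@H](Nc1ccccc1F)C1=CCOC1=O`, which in a functional assay on KB cells (Homo sapiens) for cytotoxicity, read by sulforhodamine B assay (a higher number here means a weaker inhibitor, a lower number a stronger inhibitor), gives 4740 nM
- compound 2 `C=C1[C@@H](OC(C)=O)C[C@@H]2[C@](C)(COC=O)[C@H](OC(C)=O)CC[C@@]2(C)[C@@H]1C[C@@H](Nc1ccccc1C(=O)O)C1=CCOC1=O`, which gives 42500 nM
- compound 3 `C=C1CC[C@@H]2[C@](C)(CO[Si](C)(C)C(C)(C)C)[C@H](OC(C)=O)CC[C@@]2(C)[C@@H]1C/C=C1/C(=O)OC[C@H]1OC(C)=O`, which gives 5050 nM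

Compound 1 has the lowest of the three numbers. Compound 3 sits so close to it that the two cannot be told apart, while compound 2 lies well beyond the scatter, at a clearly higher number; compound 2 differs from compound 1 in more than one place, so no single step can be read from that pair.

The unmeasured compound 4 `C=C1[C@@H](OC(C)=O)C[C@@H]2[C@](C)(CO[Si](C)(C)C(C)(C)C)[C@H](OC(C)=O)CC[C@@]2(C)[C@@H]1C[C@@H](Nc1ccc(C(=O)O)cc1)C1=CCOC1=O` keeps the whole core of compound 1 and changes only the group on the amine nitrogen: 4-carboxyphenyl in place of 2-fluorophenyl on an amine nitrogen. Within the data shown here, the entering group is a 4-carboxyphenyl, and the one measured compound that also carries a carboxylic acid on the amine-linked ring, compound 2, gives the highest number seen. On that basis the step from compound 1 is expected to run toward a higher number, beyond the scatter, of about a 4.2-fold higher number from compound 1 to compound 4 (0.63 log units; beyond the scatter). Compound 4 is therefore estimated at 20000 nM, likely between 6000 nM and 60000 nM.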

Compound 4, half-maximal inhibitory concentration: 5540 nM
Compound 4: the middle estimate sits 3.6-fold (0.56 log units) above what was measured; measured number outside the range, below it.
By their numbers in this assay, from the lowest: compounds 1, 3 and 4 (each within the scatter of the next); then compound 2.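

Among these compounds, the step of a 1.2-fold higher number from compound 1 to compound 4 (0.07 log units; within the scatter) in this assay is the first reading of a single change, since no earlier pair differed in only one place. On this core, with the amine nitrogen as the place of change, 4-carboxyphenyl and 2-fluorophenyl cannot be told apart in this cell test, even though the two groups differ in their atoms and in their hydrogen-bond donor and acceptor counts. Nothing measured here offers an explanation for this result.

The compounds shown leave open whether a plain phenyl, a pyridine ring or a longer alkyl chain on the amine nitrogen would read the same. They also leave open whether 2-fluorophenyl and 4-carboxyphenyl would still read alike on the core of compound 2.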